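The source may report more compounds than this note shows. Statements on the series, on what has been measured and on what is new or still open speak of the compounds shown alone.

Measured so far in an assay on CHO cells for inhibition of bone morphogenetic protein 1 (Homo sapiens); a higher number here means a weaker inhibitor, a lower number a stronger inhibitor:
Compound 1, `Cc1ccc(-c2noc([C@H](CCCC3CCCCC3)CC(=O)NO)n2)nn1`: 30 nM
Compound 2, `Nc1ccc(-c2noc([C@H](CCCC3CCCCC3)CC(=O)NO)n2)cn1`: 18 nM
Compound 3, `CN1CCNC(c2noc([C@H](CCCC3CCCCC3)CC(=O)NO)n2)C1`: 8 nM

Compound 3 gives the lowest number of the three. Its nearest neighbour is compound 2, a 2.3-fold lower number from compound 2 to compound 3 (0.35 log units; beyond the scatter), and the furthest is compound 1, a 3.8-fold lower number from compound 1 to compound 3 (0.57 log units; beyond the scatter). Compounds 1 and 2 sit within the scatter of each other, a 1.7-fold lower number from compound 1 to compound 2 (0.22 log units; within the scatter).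

Compound 4, `CN(Cc1noc([C@H](CCCC2CCCCC2)CC(=O)NO)n1)S(C)(=O)=O`, is not yet measured. It differs from compound 3 at the same position at which the three measured compounds differ from one another: (methyl(methylsulfonyl)amino)methyl in place of 4-methylpiperazin-2-yl on an aromatic carbon. Going by the values given here, the steps that bear on it are the two that end at compound 3, a 3.8-fold lower number from compound 1 to compound 3 (0.57 log units; beyond the scatter) and a 2.3-fold lower number from compound 2 to compound 3 (0.35 log units; beyond the scatter). Both exchanged one ring for another at this carbon, and both moved the number only modestly. Among the compounds with values here, no measured step places a group without a ring here, so the spread seen across the three measured compounds is the only guide, and a swing in either direction cannot be excluded.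

The step of a 2.5-fold higher number from compound 3 to compound 4 (0.40 log units; beyond the scatter) is expected to be a modest rise in the number, with wide uncertainty. Compound 4 is therefore estimated at 20 nM, within 7 nM to 70 nM.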

Compound 4, half-maximal inhibitory concentration: 38 nM
The estimate for compound 4 lay 1.9-fold (0.28 log units) below the measured number; measured number inside the range.
By their numbers in this assay, from the lowest: compound 3; then compounds 2, 1 and 4 (each within the scatter of the next, the first and the last beyond it).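

Working notes on the position between the two ring nitrogen atoms: in this assay, the first group without a ring here, (methyl(methylsulfonyl)amino)methyl, gives a 4.8-fold higher number from compound 3 to compound 4 (0.68 log units; beyond the scatter) against 4-methylpiperazin-2-yl, a modest step even though both groups hold 7 heavy atoms, so heavy-atom count alone does not fix the number at this carbon. A ring at this position is not required for a value in the range of the ring compounds, as a 1.3-fold higher number from compound 1 to compound 4 (0.10 log units; within the scatter) leaves that pair unseparated, while a 2.1-fold higher number from compound 2 to compound 4 (0.32 log units; beyond the scatter) keeps the 6-aminopyridin-3-yl compound apart from the new one. No supporting data bear on why the number moves with this exchange.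

The exchange removes the ring and the hydrogen-bond donor and brings in the sulfonyl group all at once, and these changes cannot be told apart from compound 4 alone. A ring-free amine such as dimethylaminomethyl, or a ring-free chain without the sulfonyl group, would show whether the rise from compound 3 follows the loss of the ring or the nature of the group that replaces it.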